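This account rests on a few compounds, and the source may have more. Where it says the series, first, only, none or still open, it means among the compounds named here.

Measured compounds in a toxicity assay on MDCK cells (Canis lupus familiaris) for cytotoxicity, read by crystal violet staining, with a stated time of 48 h; on this read-out higher numbers stand for lower toxicity in this test and lower numbers for higher toxicity in this test:
compound 1 `CCc1ccc2[nH]c(=O)c(CN(Cc3ccc(C(C)(C)C)cc3)Cc3ccc(F)c(F)c3)cc2c1`: > 33000 nM, a limit of the assay
compound 2 `Cc1ccc2cc(CN(Cc3ccc(F)cc3)C(=O)c3ccccc3)c(=O)[nH]c2c1`: > 33000 nM, a limit of the assay
compound 3 `Cc1ccc2cc(CN(Cc3ccc(C(C)(C)C)cc3)CC3CCCCC3)c(=O)[nH]c2c1`: > 10000 nM, a limit of the assay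

Every value here is a limit and not a number. Compound 1 stands at the limit of > 33000 nM in this assay, at which 2 of the 3 values shown sit. Compound 3 stands at the limit of > 10000 nM in this assay, at which 1 of the 3 values shown sits. Within the data shown here, no two measured compounds differ in a single place, so no step size is known.

Compound 4 `CCc1ccc2[nH]c(=O)c(CN(Cc3ccc(O)cc3)Cc3ccc(C(C)(C)C)cc3)cc2c1` differs from compound 1 by 4-hydroxyphenyl in place of 3,4-difluorophenyl on a saturated chain carbon bound to an amine nitrogen. Among the measured compounds shown here, with no measured step to lean on, the expectation for compound 4 rests on the three limits alone, and the expected step in this assay is a step that the limit leaves unreadable from compound 1 to compound 4, that is none beyond the scatter. Compound 4 is therefore expected to give 50000 nM in this assay, within 20000 nM to 200000 nM, most likely reported once more as a limit.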

Compound 4, half-maximal cytotoxic concentration: > 10000 nM
Compound 4: no number, only a limit (the forecaster's own chance of this, stated with the estimate: 85%); the middle value is on the limit's open side.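

Compound 1 gives > 33000 nM, a limit. Compound 4 gives > 10000 nM, also a limit, so no step can be read between compound 1 and compound 4. The compounds shown leave open where any actual half-maximal cytotoxic concentration lies.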